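Compound 4: trifluoromethyl in place of bromo

A few compounds are considered here, and "the series" means these few. Any claim that something is new, unique, unknown or untested is made for them only; others in the source may bear on it.

Three measured compounds share one core. Compound 1 `C=CC(=O)Nc1cccc(NC(=O)CSc2nc(Nc3ccccc3)c3ccccc3n2)c1` gives 7310 nM in a functional assay on MGC-803 cells (Homo sapiens) for inhibition, read by MTT assay, with a stated time of 72 h; on this read-out higher numbers stand for weaker inhibition and lower numbers for stronger inhibition. Compound 2 `O=C(CSc1nc(Nc2ccccc2)c2ccccc2n1)Nc1ccc(F)cc1` reaches only the limit (the limit of > 50000 nM in this assay, at which 1 of the 3 values shown sits); in this assay compound 2 gives > 50000 nM. Compound 3 `O=C(CSc1nc(Nc2ccccc2)c2ccccc2n1)Nc1ccc(Br)cc1` gives 19300 nM, the highest of the two numbers measured, with a 2.6-fold higher number from compound 1 to compound 3 (0.42 log units; beyond the scatter). Compound 4 `O=C(CSc1nc(Nc2ccccc2)c2ccccc2n1)Nc1ccc(C(F)(F)F)cc1` differs from compound 3 by trifluoromethyl in place of bromo on an aromatic carbon. The nearest measured step is an at least 2.5-fold lower number from compound 2 to compound 3 (0.41 log units; beyond the scatter), a change of the same kind on the same ring; the step of an at least 6.8-fold higher number from compound 1 to compound 2 (0.83 log units; beyond the scatter) swaps a whole substituent and bears less on this exchange. Neither fixes the size of a bromo-to-trifluoromethyl change, so for compound 4 a step within the scatter is expected, a 1.2-fold lower number from compound 3 to compound 4 (0.08 log units; within the scatter). Compound 4 is estimated at 16000 nM, between 5000 nM and 50000 nM.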

Compound 4, half-maximal inhibitory concentration: 8670 nM
Compound 4: the middle estimate sits 1.8-fold (0.27 log units) above what was measured; the range from low to high includes it.
By their numbers in this assay, from the lowest: compounds 1 and 4 (each within the scatter of the next); then compound 3. At a limit, above all of these: compound 2.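

Trifluoromethyl on this aromatic carbon lowers the number further than bromo does (a 2.2-fold lower number from compound 3 to compound 4 (0.35 log units; beyond the scatter)) and further than fluoro does (an at least 5.7-fold lower number from compound 2 to compound 4 (0.76 log units; beyond the scatter)), so the size of this group's exchange is now visible beyond the scatter. The comparison with fluoro rests on a limit, not a number: the limit of > 50000 nM in this assay, at which 1 of the 4 values shown sits. Within the data shown here, compound 4 is also the first compound with a 4-substituted phenyl to come level with compound 1 (a 1.2-fold higher number from compound 1 to compound 4 (0.07 log units; within the scatter)).

As far as these compounds go, what an amine, a methoxy group or a carboxylic acid would give on this carbon stays open.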